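The source may report more compounds than this note shows. Statements on the series, on what has been measured and on what is new or still open speak of the compounds shown alone.

Compound 1 `O=C1C(=O)N(CN(c2ccccc2)c2ccccc2)c2ccccc21` and compound 3 `O=C1C(=O)N(CN(c2ccccc2)c2ccccc2)c2cccc(Br)c21` share one core and differ in a single place: the change (hydrogen in place of bromo on an aromatic carbon). In a functional assay on MCF7 cells (Homo sapiens) for cytotoxicity, read by sulforhodamine B assay, with a stated time of 48 h (a lower number here means a stronger inhibitor of growth, a higher number a weaker inhibitor of growth), compound 3 gives 110000 nM, while compound 1 gives 23700 nM, so the change makes a 4.6-fold lower number from compound 3 to compound 1 (0.67 log units; beyond the scatter). Compound 2 `Cc1ccc2nc(/N=C3\C(=O)N(CN(C)C)c4cccc(Br)c43)sc2c1` is built on another core, and the difference between the two cores is not broken down here; in this assay compound 2 gives 18000 nM, a number that stands close to that of compound 1 and well apart from that of compound 3. Compound 4 `Cc1ccc2nc(/N=C3\C(=O)N(CN(C)C)c4ccccc43)sc2c1` has not yet been measured. Among the compounds with values here, it arises from compound 2 by the change (hydrogen in place of bromo on an aromatic carbon), which is the same change as the one from compound 3 to compound 1, at the same kind of place. Because that earlier step gave a 4.6-fold lower number from compound 3 to compound 1 (0.67 log units; beyond the scatter), a step of similar direction but somewhat smaller size, a 2.6-fold lower number from compound 2 to compound 4 (0.41 log units; beyond the scatter), is expected from compound 2 to compound 4, smaller since the two cores differ and one example is a thin basis. The estimate for compound 4 in this assay is therefore 7000 nM, with a range from 2500 nM to 20000 nM.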

Compound 4, concentration for 50% growth inhibition: 29200 nM
Compound 4: middle estimate off by 4.2-fold (0.62 log units), on the low side; the measured number lies above the stated range.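

On the core of compound 2, putting hydrogen in place of bromo on the aromatic carbon gives a 1.6-fold higher number from compound 2 to compound 4 (0.21 log units; within the scatter), so in this assay this pair shows no clear effect of the change. The clear gain seen on the core of compound 1 therefore did not carry over to the core of compound 2, and the two steps really do differ: the same change on two cores in this assay, a 4.6-fold lower number (0.67 log units; beyond the scatter) from compound 3 to compound 1 and a 1.6-fold higher number (0.21 log units; within the scatter) from compound 2 to compound 4, 7.5-fold (0.88 log units) apart, beyond the scatter of two such steps

Within the data shown here, this shows that the effect of this swap depends on the core that carries it, so a step measured on one core is a poor guide to the step on the other, but with only two pairs it gives no general rule and does not reveal what in the cores causes the gap.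

The compounds shown leave open what a chloro or methoxy group in the same place would do on either core. No compound shown splits the difference between the two cores into single changes, so which part of the core decides the outcome remains unknown.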